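This account rests on a few compounds, and the source may have more. Where it says the series, first, only, none or still open, it means among the compounds named here.

Measured so far:
Compound 1 `CC(C)(C)c1ccc(CNCCCNS(=O)(=O)c2cc(C(F)(F)F)cc(C(F)(F)F)c2)cc1` gives 2800 nM in a functional assay on A-431 cells (Homo sapiens) for inhibition, read by MTT assay, with a stated time of 72 h; on this read-out higher numbers stand for weaker inhibition of growth and lower numbers for stronger inhibition of growth.
Compound 2 `O=S(=O)(NCCNCc1ccc(-c2ccccc2)cc1)c1cc(C(F)(F)F)cc(C(F)(F)F)c1` gives 2400 nM in this assay.
Compound 3 `O=S(=O)(NCCCNCc1ccc(-c2ccccc2)cc1)c1cc(C(F)(F)F)cc(C(F)(F)F)c1` gives 2600 nM in this assay.

All three numbers lie within the usual scatter of one another, so no order among them is drawn. Compound 3 and compound 1 share a core and differ by tert-butyl in place of phenyl on an aromatic carbon; that change gave a 1.1-fold higher number from compound 3 to compound 1 (0.03 log units; within the scatter). The difference between the cores of compound 2 and compound 3 is not broken down here.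

Compound 4 `CC(C)(C)c1ccc(CNCCNS(=O)(=O)c2cc(C(F)(F)F)cc(C(F)(F)F)c2)cc1` is not yet measured. It derives from compound 2 by tert-butyl in place of phenyl on an aromatic carbon, the same change as from compound 3 to compound 1, at the same place. For compound 4 the step is expected to be a 1.1-fold higher number from compound 2 to compound 4 (0.05 log units; within the scatter), because the earlier occurrence of this change gave a 1.1-fold higher number from compound 3 to compound 1 (0.03 log units; within the scatter) and a similar outcome is assumed here. Compound 4 is therefore estimated at 2700 nM in this assay, with a range from 1500 nM to 4800 nM.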

Compound 4, concentration for 50% growth inhibition: 16000 nM
For compound 4 the middle estimate is 5.9-fold (0.77 log units) below the measured one; the measured number lies above the stated range.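

In this assay, tert-butyl in place of phenyl on an aromatic carbon gives a 6.7-fold higher number from compound 2 to compound 4 (0.82 log units; beyond the scatter), so the change does not carry over unchanged from one core to the other: the same change on two cores in this assay, a 1.1-fold higher number (0.03 log units; within the scatter) from compound 3 to compound 1 and a 6.7-fold higher number (0.82 log units; beyond the scatter) from compound 2 to compound 4, 6.2-fold (0.79 log units) apart, beyond the scatter of two such steps.
The large step holds for this pair only, and the pair of compound 3 and compound 1 goes against any general loss of growth inhibition on this change.
Two pairs show that the outcome depends on the core, but they give no rule for other cores and no cause for the gap.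

As far as these compounds go, it remains open whether the gap follows the chain that separates the two cores. A longer chain, or a chlorine or methoxy group in place of tert-butyl, could test how far this dependence extends.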